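The source may hold more compounds than are shown below. What is called first, only, known or untested is meant among the compounds shown, and "the series" means these compounds.

Compound 1 `CC(C)(C)c1[nH]cnc1/C=c1\[nH]c(=O)/c(=C/c2cccc(Oc3ccc(F)cc3)c2)[nH]c1=O` gives 3.2 nM in a functional assay on BXPC-3 cells (Homo sapiens) for cytotoxicity, read by MTT assay, with a stated time of 72 h; a higher number here means a weaker inhibitor, a lower number a stronger inhibitor. Compound 2 `CC(C)c1[nH]cnc1/C=c1\[nH]c(=O)/c(=C/c2cccc(Oc3ccc(F)cc3)c2)[nH]c1=O` differs from it by hydrogen in place of methyl on a saturated chain carbon bound to an aromatic carbon and two saturated chain carbons; in this assay compound 2 gives 3.4 nM, a step of a 1.1-fold higher number from compound 1 to compound 2 (0.03 log units; within the scatter). Compound 3 `CC(C)c1[nH]cnc1/C=c1\[nH]c(=O)/c(=C/c2cccc(C(=O)c3ccc(F)cc3)c2)[nH]c1=O` carries (4-fluorophenyl)carbonyl in place of 4-fluorophenoxy on an aromatic carbon, and in this assay compound 3 gives 0.6 nM, the step being a 5.7-fold lower number from compound 2 to compound 3 (0.75 log units; beyond the scatter). Compound 3 thus stands at the lowest of the three numbers, the other two lying beyond the scatter above it. Compound 4 `Cc1ccc(/C=c2\[nH]c(=O)/c(=C/c3cccc(C(=O)c4ccc(F)cc4)c3)[nH]c2=O)o1` alters a different part of the shared core: 5-methylfuran-2-yl in place of 5-isopropyl-1H-imidazol-4-yl on a double-bonded chain carbon bound to an aromatic carbon. Neither measured step touches this position; one concerns the saturated chain carbon, the other the 4-fluorophenoxy group, so nothing measured speaks to swapping the 5-isopropyl-1H-imidazol-4-yl group, with its hydrogen-bond donor, for 5-methylfuran-2-yl. A modest rise in the number is therefore expected, as a 5.0-fold higher number from compound 3 to compound 4 (0.70 log units; beyond the scatter). Compound 4 is estimated at 3 nM, between 0.8 nM and 12 nM.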

Compound 4, half-maximal inhibitory concentration: 3.7 nM
The estimate for compound 4 lay 1.2-fold (0.09 log units) below the measured number; low and high end bracket the measured number.
By their numbers in this assay, from the lowest: compound 3; then compounds 1, 2 and 4 (each within the scatter of the next).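

In this assay, among these compounds, 5-methylfuran-2-yl in place of 5-isopropyl-1H-imidazol-4-yl gives a 6.2-fold higher number from compound 3 to compound 4 (0.79 log units; beyond the scatter), which shows that this double-bonded chain carbon bound to an aromatic carbon carries a group that matters to the number, something the earlier steps, made elsewhere on the shared core, could not show. The step changes the ring, its alkyl group and the hydrogen-bond donor count together, so it cannot assign the rise to any one of them. No evidence is available to explain the rise.

The compounds shown leave open how a 5-methyl-1H-pyrrol-2-yl or a 5-methylthiophen-2-yl group would fare on this carbon. They also leave open whether the same swap would give a step of similar size with 4-fluorophenoxy in place of (4-fluorophenyl)carbonyl.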